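The source may hold more compounds than are shown below. What is called first, only, known or untested is meant among the compounds shown, and "the series" means these compounds.

Working notes on the series.

Three compounds of the shared core have numbers in an assay on microsomes from liver for inhibition of sterol O-acyltransferase 1 (Rattus norvegicus); on this read-out lower numbers stand for stronger inhibition and higher numbers for weaker inhibition. Compound 1 `C[C@]1(O)CC(=O)OC(CSc2nc(-c3ccccc3)c(-c3ccccc3)[nH]2)C1` gives 140 nM in this assay. Compound 2 `O=C1CCC(CSc2nc(-c3ccccc3)c(-c3ccccc3)[nH]2)N1` gives 360 nM in this assay. Compound 3 `c1ccc(-c2nc(SCC3OCCCO3)[nH]c2-c2ccccc2)cc1` gives 180 nM in this assay, the second highest of the three, with compound 1 nearest and compound 2 furthest, both within the scatter.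

Compound 4 `c1ccc(-c2nc(SCC3OCCO3)[nH]c2-c2ccccc2)cc1` differs from compound 3 by a group of 5 heavy atoms (3 carbon, 2 oxygen; one five-membered non-aromatic ring with 2 hetero atoms) in place of a group of 6 heavy atoms (4 carbon, 2 oxygen; one six-membered non-aromatic ring with 2 hetero atoms), on a saturated chain carbon bound to a sulfur. The measured steps that bear on it are the three exchanges on the same saturated chain carbon bound to a sulfur: a 2.6-fold higher number from compound 1 to compound 2 (0.41 log units; beyond the scatter), a 1.3-fold higher number from compound 1 to compound 3 (0.11 log units; within the scatter) and a 2.0-fold lower number from compound 2 to compound 3 (0.30 log units; within the scatter). Among the compounds with values here, only the step from compound 1 to compound 2, which also shortens a six-membered ring to a five-membered one, lies beyond the scatter, and it is modest; the two others lie within it. A step of at most modest size is therefore expected in this assay, with a slight lean towards a higher number.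

Compound 4 is expected to give 250 nM in this assay, in the range 120 nM to 550 nM, an expected step of a 1.4-fold higher number from compound 3 to compound 4 (0.14 log units; within the scatter).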

Compound 4, half-maximal inhibitory concentration: 530 nM
Estimate against measurement, compound 4: 2.1-fold (0.33 log units) below, within the range that was stated.
By their numbers in this assay, from the lowest: compounds 1, 3, 2 and 4 (each within the scatter of the next, the first and the last beyond it).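

The exchange of the six-membered ring with 2 hetero atoms for 1,3-dioxolan-2-yl, on a saturated chain carbon bound to a sulfur, leaves the hydrogen-bond donor and acceptor counts unchanged, yet in this assay it gives a 2.9-fold higher number from compound 3 to compound 4 (0.47 log units; beyond the scatter), so this position responds to a change confined to the ring. Compound 4 also stands apart from the top of the series, with a 3.8-fold higher number from compound 1 to compound 4 (0.58 log units; beyond the scatter), but not from the other five-membered ring, with a 1.5-fold higher number from compound 2 to compound 4 (0.17 log units; within the scatter); a ring-size reading stays loose, since the step from compound 2 to compound 3 lies within the scatter. No measurement at hand accounts for these steps.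

Open, as far as these compounds go, is whether an acyclic dimethoxymethyl group on the same carbon would side with compound 3 or compound 4. Also open, from the compounds shown here alone, is how an amine or a carboxylic acid would read there.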